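Cytotoxicity notes on the aryl ether series

The source may report more compounds than this note shows. Statements on the series, on what has been measured and on what is new or still open speak of the compounds shown alone.

The shared core of the series is shown by compound 1 `CCOC(=O)c1cc(-c2cccc(OCc3ccccc3)c2)on1`. In an ADME assay on Vero cells (Chlorocebus sabaeus) for cytotoxicity, with a stated time of 72 h (a higher number here means a weaker inhibitor, a lower number a stronger inhibitor), compound 1 gives only a limit of the assay, > 128000 nM. Compound 2 `CCOC(=O)c1cc(-c2cccc(OCc3cccc(F)c3)c2)on1` carries fluoro in place of hydrogen on an aromatic carbon. In this assay compound 2 likewise gives only a limit, > 128000 nM. Compound 3 `CCOC(=O)c1cc(-c2cccc(OCc3cccc(OC)c3)c2)on1` carries methoxy in place of hydrogen on an aromatic carbon. In this assay compound 3 again gives only a limit, > 128000 nM. Compound 3 thus stands where every measured value of the series stands, at the limit of > 128000 nM in this assay, at which 3 of the 3 values shown sit. The steps a step that the two limits leave unreadable from compound 1 to compound 2, a step that the two limits leave unreadable from compound 1 to compound 3 and a step that the two limits leave unreadable from compound 2 to compound 3 are all unreadable in size, both ends being limits.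

Compound 4 `CCOC(=O)c1cc(-c2cccc(OCc3ccccc3Cl)c2)on1` is not yet measured. It differs from compound 3 by 2-chlorophenyl in place of 3-methoxyphenyl on a saturated chain carbon bound to an oxygen on an aromatic ring. Among the compounds with values here, none of the measured steps reaches a readable number, so they give no size and no direction for this change; what they do show is that three variations of the group on the saturated chain carbon all remain at the limit. The expected step of a number no higher from compound 3 to compound 4 (the limit leaves the size open) is none beyond the scatter. Compound 4 is accordingly estimated at 128000 nM, with a range from 50000 nM to 300000 nM, and is expected most likely to be reported as a limit once more.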

Compound 4, half-maximal inhibitory concentration: > 128000 nM
Compound 4 ended at the assay's limit (the forecaster's own chance of this, stated with the estimate: 85%); the middle value lies on the limit itself.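

Compound 4 also gives only a limit, so no new step can be read: its steps from compound 1, compound 2 and compound 3 cannot be sized, both ends being limits, and all values stand at one point: the limit of > 128000 nM in this assay, at which 4 of the 4 values shown sit.

The compounds shown leave open whether any variation of the group on the saturated chain carbon reaches a readable number in this assay.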